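Cyclopropyl Replaces 3-Fluorophenyl: Cytotoxicity Expected Unchanged

The source may report more compounds than this note shows. Statements on the series, on what has been measured and on what is new or still open speak of the compounds shown alone.

Measured compounds in an ADME assay on HeLa cells (Homo sapiens) for cytotoxicity, read by sulforhodamine B assay, with a stated time of 48 h, tested at 10 uM; on this read-out higher numbers stand for more inhibition at the one concentration tested (going by the name of the read-out) and lower numbers for less inhibition:
- compound 1 `COc1nc2ccc(Br)cc2cc1C(c1ccccc1)n1cc(-c2ccc(Br)cc2)nn1` gives 6.92%
- compound 2 `COc1nc2ccc(Br)cc2cc1C(c1ccccc1)n1cc(-c2cccc(F)c2)nn1` gives 9.04%

Of the two numbers shown, compound 2 holds the larger one, but the gap to compound 1, a number 2.1 percentage points higher from compound 1 to compound 2 (within the scatter), is within the scatter, so the two readings cannot be told apart in this assay. Compound 3 `COc1nc2ccc(Br)cc2cc1C(c1ccccc1)n1cc(C2CC2)nn1` differs from compound 2 in one place: cyclopropyl in place of 3-fluorophenyl on an aromatic carbon. Within the data shown here, the single measured step, a number 2.1 percentage points higher from compound 1 to compound 2 (within the scatter), swaps 4-bromophenyl for 3-fluorophenyl and stays within the scatter; it does not exchange an aromatic ring for cyclopropyl, so no measured step bears directly on this change. Both measured numbers are low, and with nothing pointing either way, no movement beyond the scatter is expected in this assay for compound 3. The estimate for compound 3 in this assay is 8%, with a range from 0% to 20%. The step this estimate implies, a number 1 percentage points lower from compound 2 to compound 3 (within the scatter), is expected to sit within the scatter.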

Compound 3, a percentage reported as inhibition, at one concentration (the size of the read-out at that concentration, not a potency): -5.84%
Compound 3: the middle estimate sits 13.8 percentage points above what was measured; measured number outside the range, below it.
By their numbers in this assay, from the lowest: compound 3; then compounds 1 and 2 (each within the scatter of the next).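

In this assay, this aromatic carbon of the five-membered ring with 3 nitrogen proves sensitive to what it carries: cyclopropyl in place of 3-fluorophenyl gives a number 14.9 percentage points lower from compound 2 to compound 3 (beyond the scatter), and cyclopropyl in place of 4-bromophenyl gives a number 12.8 percentage points lower from compound 1 to compound 3 (beyond the scatter). Among these compounds, the earlier swap of one substituted phenyl for another stayed within the scatter, so exchanging the aromatic ring for a small non-aromatic ring is the first change here to shift the reading beyond it, although the shift is modest and compound 3 reads -5.84%, a negative number on this scale. Nothing available explains this shift, which therefore remains an observation without a known cause.

This swap changes the ring size, the number of heavy atoms and aromatic character all at once, so the three compounds cannot show which of these matters. From the compounds shown here alone, it also remains open whether an unsubstituted phenyl, a cyclohexyl or a longer chain such as n-butyl would read closer to compound 2 or to compound 3 in this assay.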